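A few compounds are considered here, and "the series" means these few. Any claim that something is new, unique, unknown or untested is made for them only; others in the source may bear on it.

Three compounds share one core and differ only in the ring carried on an aromatic nitrogen. Compound 1 `Cc1cccc(-n2cc(COc3cccc(NC(=O)Nc4ccc(Cl)c(C(F)(F)F)c4)c3)nn2)c1` carries a 3-methylphenyl there and gives 7270 nM in a functional assay on HepG2 cells (Homo sapiens) for inhibition, read by MTT assay, with a stated time of 72 h; on this read-out lower numbers stand for stronger inhibition and higher numbers for weaker inhibition. Compound 2 `N#Cc1ccccc1-n1cc(COc2cccc(NC(=O)Nc3ccc(Cl)c(C(F)(F)F)c3)c2)nn1` carries a 2-cyanophenyl and gives 1970 nM. Compound 3 `O=C(Nc1cccc(OCc2cn(-c3ccccc3F)nn2)c1)Nc1ccc(Cl)c(C(F)(F)F)c1` carries a 2-fluorophenyl and gives 1520 nM, the lowest of the three numbers, though its gap to compound 2 is within the scatter and only its gap to compound 1 is beyond it.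

Compound 4 `O=C(Nc1cccc(OCc2cn(-c3cccc(Cl)c3)nn2)c1)Nc1ccc(Cl)c(C(F)(F)F)c1` differs from compound 3 by 3-chlorophenyl in place of 2-fluorophenyl on an aromatic nitrogen. Within the data shown here, the steps that bear on this are a 4.8-fold lower number from compound 1 to compound 3 (0.68 log units; beyond the scatter) and a 3.7-fold lower number from compound 1 to compound 2 (0.57 log units; beyond the scatter), both modest, while a 1.3-fold lower number from compound 2 to compound 3 (0.11 log units; within the scatter) shows that swapping one small group for another on that ring barely matters. Among the measured compounds shown here, no measured step exchanges fluoro for chloro or trades a 2-fluorophenyl for a 3-chlorophenyl, so the direction is uncertain. By its name the new ring resembles the 3-methylphenyl of compound 1, so a number between those of compound 1 and compound 3 is expected. For compound 4 this expectation means a 2.6-fold higher number from compound 3 to compound 4 (0.42 log units; beyond the scatter). For compound 4 the estimate is 4000 nM, within 1300 nM to 10000 nM.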

Compound 4, half-maximal inhibitory concentration: 2020 nM
Estimate against measurement, compound 4: 2.0-fold (0.30 log units) above; measured number inside the range.
By their numbers in this assay, from the lowest: compounds 3, 2 and 4 (each within the scatter of the next); then compound 1.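

In this assay, the step to the 3-chlorophenyl from the 2-fluorophenyl (a 1.3-fold higher number from compound 3 to compound 4 (0.12 log units; within the scatter)) and the step to it from the 2-cyanophenyl (a 1.0-fold higher number from compound 2 to compound 4 (0.01 log units; within the scatter)) both stay within the scatter, so at this position these three rings cannot be told apart, even though the group and its place on the ring both change. Chloro in place of methyl on the same ring is a larger step (a 3.6-fold lower number from compound 1 to compound 4 (0.56 log units; beyond the scatter)), so a group placed as in the 3-methylphenyl does not by itself bring the higher number of compound 1. Nothing measured here accounts for these steps. Still open, as far as these compounds go, is how the number would respond to a phenyl ring carrying an amine or a carboxylic acid. From the compounds shown here alone, a longer chain in place of the ring on the aromatic nitrogen is equally open.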